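Three Limits and a Difluorinated Newcomer

The compounds below may be only part of what the source reports. "The series", "measured", "known", "first", "only" and "open" are said of these compounds alone.

So far, in a functional assay on MCF cells (Homo sapiens) for antiproliferative activity, with a stated time of 72 h; on this read-out lower numbers stand for stronger inhibition and higher numbers for weaker inhibition (each value a limit):
Compound 1 (`OC[C@H]1O[C@@H](n2cnc3c(NCc4ccc(Br)cc4)ncnc32)[C@H](O)[C@@H]1O`): > 166000 nM
Compound 2 (`COc1ccccc1CNc1ncnc2c1ncn2[C@@H]1O[C@H](CO)[C@@H](O)[C@H]1O`): > 166000 nM
Compound 3 (`COc1cccc(CNc2ncnc3c2ncn3[C@@H]2O[C@H](CO)[C@@H](O)[C@H]2O)c1`): > 166000 nM

Compound 3 sits at > 166000 nM and that is a limit, not a number. It shares this place with the other two compounds (the limit of > 166000 nM in this assay, at which 3 of the 3 values shown sit). Compound 4 (`OC[C@H]1O[C@@H](n2cnc3c(NCc4ccc(F)cc4F)ncnc32)[C@H](O)[C@@H]1O`) has not been measured yet. It differs from compound 3 by having 2,4-difluorophenyl in place of 3-methoxyphenyl on a saturated chain carbon bound to a nitrogen on an aromatic ring.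

The three measured steps all change the group at this same place (a step that the two limits leave unreadable from compound 1 to compound 2 and a step that the two limits leave unreadable from compound 1 to compound 3 and a step that the two limits leave unreadable from compound 2 to compound 3). None of them has a readable size, so they give no direction for the new change. Going by a step that the two limits leave unreadable from compound 2 to compound 3 and the two others, no step beyond the scatter is expected in this assay and compound 4 will most likely also be reported only as a limit. The step expected here is an at least 1.1-fold lower number from compound 3 to compound 4 (0.04 log units; that floor lies within the scatter) and it is only an estimate. Three limits offer no size to lean on, so the expected range is wide and reaches toward stronger inhibition. For compound 4 the estimated value is 150000 nM with an expected range from 15000 nM to 250000 nM in all.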

Compound 4, half-maximal inhibitory concentration: > 166000 nM
Compound 4 gave a limit, no number; the forecaster's own chance of this, stated with the estimate: 70%; at least 1.1-fold (0.04 log units) between middle value and limit.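

In this assay compound 4 gives > 166000 nM, which is a limit and not a number. Its steps to compound 1, compound 2 and compound 3 cannot be read, because all four compounds share one limit: the limit of > 166000 nM in this assay, at which 4 of the 4 values shown sit.

The compounds shown leave open whether any group at this place gives a readable number in this assay, and how these four compounds truly rank.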